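The compounds below may be only part of what the source reports. "The series", "measured", "known", "first", "only" and "open" are said of these compounds alone.

Measured compounds and their values:

Compound 1, `COc1ccc2c(c1)C(CNC(C)=O)CC2`, gives 77 nM.
Compound 2, `CCCC(=O)NCC1CCCCc2ccc(OC)cc21`, gives 1 nM.
Compound 3, `CCCC(=O)NCC1CCc2ccc(OC)cc21`, gives 7.6 nM.

All three were tested in an assay for binding affinity to melatonin receptor type 1B (Gallus gallus), read by radioligand binding; a higher number here means a weaker inhibitor, a lower number a stronger inhibitor. Compound 2 stands lowest of the three, and its gap to compound 3 and to compound 1 is in each case beyond the scatter. The difference between the core of compound 2 and the core of compound 3 is not broken down here. Compound 3 and compound 1, however, share a core and differ in one place: hydrogen in place of ethyl on a saturated chain carbon bound to a carbonyl carbon. That change produced a 10-fold higher number from compound 3 to compound 1 (1.01 log units; beyond the scatter), a large step.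

The unmeasured compound 4, `COc1ccc2c(c1)C(CNC(C)=O)CCCC2`, shares its core with compound 2 and differs from it in exactly the same way: hydrogen in place of ethyl on a saturated chain carbon bound to a carbonyl carbon. The place of the change is the same in both pairs, so this is the same change made a second time, now on the lower-lying core. Among the measured compounds shown here, the only guide to its effect is the step seen from compound 3 to compound 1, and the account rests on that single precedent. With that in mind, compound 4 is expected to give a number around 10 nM in this assay, which would mean an estimated step of a 10-fold higher number from compound 2 to compound 4 (1.00 log units; beyond the scatter), with the range 4 nM to 25 nM taken as likely, because the step of a 10-fold higher number from compound 3 to compound 1 (1.01 log units; beyond the scatter) was large and well beyond the scatter.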

Compound 4, inhibition constant: 34 nM
Compound 4: middle estimate off by 3.4-fold (0.53 log units), on the low side; measured number above the stated range.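

In this assay, hydrogen in place of ethyl on a saturated chain carbon bound to a carbonyl carbon, which is the same as propylcarbonyl giving way to acetyl, raises the number on both cores, and the new case is a 34-fold higher number from compound 2 to compound 4 (1.53 log units; beyond the scatter). The direction of the change therefore carries over from one core to the other, but its size does not, and the step on the core of compound 2 is the larger of the two: the same change on two cores in this assay, a 10-fold higher number (1.01 log units; beyond the scatter) from compound 3 to compound 1 and a 34-fold higher number (1.53 log units; beyond the scatter) from compound 2 to compound 4, 3.4-fold (0.53 log units) apart, beyond the scatter of two such steps This rests on one pair per core, so it shows that the cost of the shorter chain depends on the core in these two cases, but it gives no reason for the difference and no rule for predicting the size of the step on a third core.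

The compounds shown leave open how the number moves along the chain on either core, for instance with a propionyl group, which would lie in length from acetyl to propylcarbonyl, or with a longer chain such as pentanoyl. They also leave open whether the same dependence on the core would appear with a branched acyl group, such as isobutyryl, or a cyclopropylcarbonyl group in place of the propylcarbonyl.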